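A Carbonyl in Place of a Sulfonyl at the Chain End

This account rests on a few compounds, and the source may have more. Where it says the series, first, only, none or still open, it means among the compounds named here.

Measured so far in a functional assay on A-375 cells (Homo sapiens) for cytotoxicity, read by MTT assay; a lower number here means a stronger inhibitor, a higher number a weaker inhibitor: compound 1 `O=S(=O)(NCCCNc1nccc(-c2c(-c3cccc(F)c3)nc3sccn23)n1)c1cccc(F)c1` gives 13700 nM; compound 2 `O=S(=O)(NCCNc1nccc(-c2c(-c3cccc(F)c3)nc3sccn23)n1)c1ccc(F)cc1` gives 9450 nM; compound 3 `O=C(NCCCNc1nccc(-c2c(-c3cccc(F)c3)nc3sccn23)n1)c1ccc(Cl)cc1` gives 13700 nM.

Compound 2 shows the lowest of the three numbers, yet the steps linking it to the others, a 1.4-fold lower number from compound 1 to compound 2 (0.16 log units; within the scatter) and a 1.4-fold higher number from compound 2 to compound 3 (0.16 log units; within the scatter), both lie within the scatter, so the three compounds cannot be ranked on these data.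

Compound 4 `Cc1ccc(C(=O)NCCNc2nccc(-c3c(-c4cccc(F)c4)nc4sccn34)n2)cc1` differs from compound 2 by (4-methylphenyl)carbonyl in place of (4-fluorophenyl)sulfonyl on an amine nitrogen. The measured step that bears most directly on this exchange is the same sulfonyl-to-carbonyl swap on the longer chain, no change at the digits printed from compound 1 to compound 3 (within the scatter), and the mixed change a 1.4-fold higher number from compound 2 to compound 3 (0.16 log units; within the scatter) was equally small. No step beyond the scatter is therefore expected in this assay, a 1.2-fold higher number from compound 2 to compound 4 (0.07 log units; within the scatter). Compound 4 is estimated at 11000 nM, within 5000 nM to 25000 nM.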

Compound 4, half-maximal inhibitory concentration: 5880 nM
Beside the measured number, compound 4's estimate is 1.9-fold (0.27 log units) above it; measured number inside the range.
By their numbers in this assay, from the lowest: compounds 4, 2, 1 and 3 (each within the scatter of the next, the first and the last beyond it).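

In this assay, replacing (4-fluorophenyl)sulfonyl with (4-methylphenyl)carbonyl on the amine nitrogen produces only a small step (a 1.6-fold lower number from compound 2 to compound 4 (0.21 log units; within the scatter)). Going by these compounds alone, compound 4 is nevertheless the first compound to separate from others beyond the scatter (a 2.3-fold lower number from compound 3 to compound 4 (0.37 log units; beyond the scatter); a 2.3-fold lower number from compound 1 to compound 4 (0.37 log units; beyond the scatter)), although both steps change the chain length as well as the end group, so neither can be credited to one part alone. Nothing measured here explains these steps. Still open, on these data alone, is whether a longer chain carrying (4-methylphenyl)carbonyl would hold this gain, and how an amine or a carboxylic acid at the chain end would behave.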